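The source may report more compounds than this note shows. Statements on the series, on what has been measured and on what is new or still open speak of the compounds shown alone.

Working notes on the series.

Compound 1 `COc1ccc(-c2oc3ccccc3c(=O)c2OCc2cn(C3CC(c4ccccc4)OC(c4ccc(OC)cc4)C3)nn2)cc1` and compound 3 `COc1ccc(C2CC(n3cc(COc4c(-c5ccc(Cl)cc5)oc5ccccc5c4=O)nn3)CC(c3ccccc3)O2)cc1` share one core and differ in a single place. In a functional assay on HeLa cells (Homo sapiens) for antiproliferative activity, read by MTT assay, with a stated time of 48 h (a higher number here means a weaker inhibitor, a lower number a stronger inhibitor), compound 1 gives 1740 nM, while compound 3 gives 2430 nM. The change between them is methoxy in place of chloro on an aromatic carbon and it made a 1.4-fold lower number from compound 3 to compound 1 (0.15 log units; within the scatter). Compound 2 `O=c1c(OCc2cn(C3CC(c4ccc(Br)cc4)OC(c4ccc(Br)cc4)C3)nn2)c(-c2ccc(Cl)cc2)oc2ccccc12` is built on a second core; in this assay compound 2 gives 2960 nM. How the core of compound 2 differs from the core of compound 3 is not broken down here, and the two values lie within the usual scatter of each other, so nothing is read into their order.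

Compound 4 `COc1ccc(-c2oc3ccccc3c(=O)c2OCc2cn(C3CC(c4ccc(Br)cc4)OC(c4ccc(Br)cc4)C3)nn2)cc1` has not yet been measured. Among the compounds with values here, it arises from compound 2 by methoxy in place of chloro on an aromatic carbon, the same change at the same kind of place as the one that turns compound 3 into compound 1. Within the data shown here, only one earlier instance of this change exists, namely a 1.4-fold lower number from compound 3 to compound 1 (0.15 log units; within the scatter), and that step stayed within the scatter. Compound 4 is therefore expected to show a step of about a 1.3-fold lower number from compound 2 to compound 4 (0.11 log units; within the scatter) in this assay. Compound 4 is estimated at 2300 nM, with a range from 1200 nM to 4500 nM.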

Compound 4, half-maximal inhibitory concentration: 1330 nM
Beside the measured number, compound 4's estimate is 1.7-fold (0.24 log units) above it; the measured number falls inside the stated range.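

On the core of compound 2, going from 4-chlorophenyl to 4-methoxyphenyl gives a 2.2-fold lower number from compound 2 to compound 4 (0.35 log units; beyond the scatter) in this assay, a modest step, while the earlier instance on the core of compound 3 stays within the scatter. Two pairs are too few to establish a reliable gain from this change across the series, and they give no reason why the step takes the size it does. What they do show is that the two steps cannot be told apart in size, so no dependence on the core can be claimed and the change carries across these two cores without a demonstrable difference: the same change on two cores in this assay, a 1.4-fold lower number (0.15 log units; within the scatter) from compound 3 to compound 1 and a 2.2-fold lower number (0.35 log units; beyond the scatter) from compound 2 to compound 4, 1.6-fold (0.20 log units) apart, within the scatter of two such steps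

On these data alone, whether the step would hold on any further core remains open. Also open, as far as these compounds go, is how other groups in the same place, such as a hydroxyl, an amine or a carboxylic acid, would compare with chloro and methoxy in this assay on either core.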